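The compounds below may be only part of what the source reports. "The series", "measured", "known", "first", "only" and "open" are said of these compounds alone.

Compound 1 `O=C(Nc1cccc(-n2cc(-c3ccncc3)c(-c3cc(O)cc(Cl)c3)n2)c1)Nc1ccc(Cl)c(Cl)c1` gives 91%.
Compound 2 `COc1cc(Cl)cc(-c2nn(-c3cccc(NC(=O)Nc4ccc(Cl)c(C(F)(F)F)c4)c3)cc2-c2ccncc2)c1` gives 91%.
Compound 3 `COc1cc(Cl)cc(-c2nn(-c3cccc(NC(=O)Nc4cc(C(F)(F)F)cc(C(F)(F)F)c4)c3)cc2-c2ccncc2)c1` gives 103%.

These three compounds were measured in a functional assay on ACHN cells (Homo sapiens) for inhibition, read by sulforhodamine B assay, with a stated time of 48 h, tested at 0.01 uM; a higher number here means a weaker effect of the compound at the concentration tested, a lower number a stronger effect. Compound 1 and compound 2 sit level at the digits printed, the two of them together at the low end of the three numbers, while compound 3 lies higher by an amount beyond the scatter. Among the compounds with values here, no pair among them differs in a single place, so no step between measured compounds can be read off.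

Compound 4 `COc1cc(Cl)cc(-c2nn(-c3cccc(NC(=O)Nc4ccc(Cl)c(Cl)c4)c3)cc2-c2ccncc2)c1` is the compound still to be measured. Relative to compound 1 the change is methyl in place of hydrogen on an oxygen on an aromatic ring. Compound 2 already carries the methoxy group on its own ring and gives 91% in this assay, the same reading at the digits printed as compound 1. On that basis the step from compound 1 to compound 4 is expected to be a number 2 percentage points higher from compound 1 to compound 4 (within the scatter), that is, no change beyond the scatter. Compound 4 is therefore expected to give about 93% in this assay, within a range from 82% to 104%.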

Compound 4, a percentage reported as activity, at one concentration (the size of the read-out at that concentration, not a potency): 102%
For compound 4 the middle estimate is 9 percentage points below the measured one; the range from low to high includes it.
By their numbers in this assay, from the lowest: compounds 1 and 2 (each within the scatter of the next); then compounds 4 and 3 (each within the scatter of the next).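

In this assay, hydroxy to methoxy on the 3-chloro-5-hydroxyphenyl ring gives a number 11 percentage points higher from compound 1 to compound 4 (beyond the scatter) and so moves the reading to a weaker effect at the concentration tested, which shows that methyl on this oxygen is not without consequence. With methoxy held in place, chloro in place of trifluoromethyl on an aromatic carbon gives a number 11 percentage points higher from compound 2 to compound 4 (beyond the scatter) in the same direction, so this second single change also registers. No measured evidence here accounts for either step.

On these data alone, whether ethyl or a longer chain on this oxygen, or an amine in place of the hydroxy, would read like methoxy remains open. As far as these compounds go, it is also open whether hydroxy to methoxy would give the same step with trifluoromethyl kept in place of chloro.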